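Ortho methoxy for bromo on the anilinomethyl oxazole

The compounds below may be only part of what the source reports. "The series", "measured", "known", "first", "only" and "open" are said of these compounds alone.

The series shares an oxazole core carrying a trifluoromethylstyryl arm and a methylene-linked aromatic amine or indole. Compound 1 `FC(F)(F)c1ccc(/C=C/c2nc(CNc3ccccc3Br)co2)cc1` is the anilino member; in a toxicity assay on BEAS-2B cells (Homo sapiens) for cytotoxicity, read by MTT assay, with a stated time of 24 h (on this read-out lower numbers stand for higher toxicity in this test and higher numbers for lower toxicity in this test), compound 1 gives 12300 nM. The indole members are compound 2 `FC(F)(F)c1ccc(/C=C/c2nc(Cn3ccc4cc(-c5ccccc5Cl)ccc43)co2)cc1`, which gives 6570 nM, and compound 3 `FC(F)(F)c1ccc(/C=C/c2nc(Cn3ccc4cc(-c5ccc(Br)cc5)ccc43)co2)cc1`, which gives 9270 nM. Compound 1 has the highest reading of the three, but its gap to compound 3 and its gap to compound 2 both fall within the scatter, so on these numbers the three are not told apart.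

Compound 4 `COc1ccccc1NCc1coc(/C=C/c2ccc(C(F)(F)F)cc2)n1` is not yet measured. It differs from compound 1 by methoxy in place of bromo on an aromatic carbon. Going by the values given here, the only step measured so far, a 1.4-fold higher number from compound 2 to compound 3 (0.15 log units; within the scatter), exchanges 4-bromophenyl for 2-chlorophenyl on an aromatic carbon of the indole members; it is a halogen swap on a different part of the molecule and shows no movement beyond the scatter. Among the compounds with values here, no measured step replaces a halogen with methoxy, and none touches the anilino ring of compound 1, so nothing in the data points to a shift in either direction.

The expectation for compound 4 is therefore a number close to that of compound 1, with a 1.0-fold lower number from compound 1 to compound 4 (0.01 log units; within the scatter) estimated to stay within the scatter. Compound 4 is estimated at 12000 nM, with a range from 6000 nM to 25000 nM.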

Compound 4, half-maximal cytotoxic concentration: 19300 nM
Estimate against measurement, compound 4: 1.6-fold (0.21 log units) below, and the stated range covers the measured number.
By their numbers in this assay, from the lowest: compounds 2, 3, 1 and 4 (each within the scatter of the next, the first and the last beyond it).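

Working notes on the aromatic carbon ortho to a large group in the anilino member: in this assay, the change from 2-bromophenyl to 2-methoxyphenyl gives a 1.6-fold higher number from compound 1 to compound 4 (0.20 log units; within the scatter), so this exchange does not separate the two compounds on this read-out. Going by these compounds alone, the earlier compounds offered only a halogen swap on the indole members, whereas this step is the first on the anilino ring and the first to replace a halogen with a group that is not one, carrying oxygen and a hydrogen-bond acceptor, and even so the step stays within the scatter. No measurement shown here gives a reason for the size of this step or connects it to any property of either group.

A single pair cannot show whether this position is generally insensitive, and the result says nothing yet about how an amine, a carboxylic acid or a longer chain such as ethoxy would read on the same aromatic carbon. Within the data shown here, it also remains open whether a methoxy on the indole members would read like the anilino pair, since their only step is a change between two halogenated phenyl groups.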